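A few compounds are considered here, and "the series" means these few. Any claim that something is new, unique, unknown or untested is made for them only; others in the source may bear on it.

Working notes on the series. Compound 2 `Nc1cc(F)ccc1NC(=O)c1ccc(CSc2nc(Nc3cc[nH]n3)c3cccn3n2)cc1` gives 731 nM in a functional assay on HCT-116 cells (Homo sapiens) for antiproliferative activity, read by luminescence, with a stated time of 72 h, tested at 1 uM (a lower number here means a stronger inhibitor, a higher number a weaker inhibitor), the lower of the two numbers held so far. Compound 1 `Cc1cc(Nc2nc(SCc3ccc(C(=O)Nc4ccccc4N)cc3)nn3cccc23)n[nH]1` gives 959 nM in this assay, and the two values lie within the scatter of each other, so compound 2 cannot be set apart from compound 1 on these numbers. Compound 3 `Cc1cccnc1Nc1nc(SCc2ccc(C(=O)Nc3ccc(F)cc3N)cc2)nn2cccc12` has not yet been measured. It differs from compound 2 in one place: 3-methylpyridin-2-yl in place of 1H-pyrazol-3-yl on a nitrogen on an aromatic ring. For the measured compounds named here, no step between two measured compounds covers this exchange, and compound 1 and compound 2 differ in more than one place, so they give no direct guide. For compound 3 a moderate loss of potency is expected, and the expected step is a 2.2-fold higher number from compound 2 to compound 3 (0.34 log units; beyond the scatter), an estimate that carries some uncertainty in either direction. The estimate for compound 3 in this assay is 1600 nM, with a range from 500 nM to 5000 nM.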

Compound 3, half-maximal inhibitory concentration: 857 nM
For compound 3 the middle estimate is 1.9-fold (0.27 log units) above the measured one; the measured number falls inside the stated range.
By their numbers in this assay, from the lowest: compounds 2, 3 and 1 (each within the scatter of the next).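

For the compounds shown here, the exchange on a nitrogen on an aromatic ring gives the first one-place comparison: in this assay the step is a 1.2-fold higher number from compound 2 to compound 3 (0.07 log units; within the scatter), so 3-methylpyridin-2-yl and 1H-pyrazol-3-yl cannot be told apart on these numbers. At this place, a six-membered aromatic ring with no hydrogen-bond donor and a five-membered aromatic ring with a hydrogen-bond donor therefore give values within the scatter of each other. No measurement at hand offers an explanation of this result.

Open, from the compounds shown here alone, is whether an aromatic ring on this nitrogen matters at all, as a simple methyl group in its place would show, and whether the methyl of 3-methylpyridin-2-yl contributes anything compared with plain pyridin-2-yl. Equally open, going by these compounds, is how a ring carrying an amine or a carboxylic acid would read in this assay.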